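A few compounds are considered here, and "the series" means these few. Any claim that something is new, unique, unknown or untested is made for them only; others in the source may bear on it.

For the measured compounds named here, in a functional assay on A549 cells (Homo sapiens) for cytotoxicity (a lower number here means a stronger inhibitor, a higher number a weaker inhibitor), compound 1 `C=C/C=C\[C@H](C)[C@H](OC(N)=O)[C@@H](C)[C@H](O)[C@@H](C)C/C(C)=C\[C@H](C)[C@@H](O)[C@@H](C)/C=C\CCc1cccc(F)c1` gives 650 nM and compound 2 `C=C/C=C\[C@H](C)[C@H](OC(N)=O)[C@@H](C)[C@H](O)[C@@H](C)C/C(C)=C\[C@H](C)[C@@H](O)[C@@H](C)/C=C\CCc1sccc1C` gives 790 nM, so compound 2 stands within the usual scatter of the only other measured compound. Compound 3 `C=C/C=C\[C@H](C)[C@H](OC(N)=O)[C@@H](C)[C@H](O)[C@@H](C)C/C(C)=C\[C@H](C)[C@@H](O)[C@@H](C)/C=C\CCc1cccc(O)c1` carries 3-hydroxyphenyl in place of 3-methylthiophen-2-yl on a saturated chain carbon, two bonds along the chain from a double-bonded chain carbon. Going by the values given here, one measured step bears on this change, a 1.2-fold higher number from compound 1 to compound 2 (0.08 log units; within the scatter), which exchanged 3-fluorophenyl for 3-methylthiophen-2-yl at the same place. Among the compounds with values here, no measured compound yet shows what 3-hydroxyphenyl does there, so this single step is thin support. On it, no change beyond the scatter is expected in this assay, in either direction. The estimated step is a 1.1-fold lower number from compound 2 to compound 3 (0.05 log units; within the scatter). The expected value for compound 3 is 700 nM, with an estimated range of 300 nM to 1600 nM.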

Compound 3, half-maximal inhibitory concentration: 190 nM
Compound 3: the middle estimate sits 3.7-fold (0.57 log units) above what was measured, outside the stated range (below it).
By their numbers in this assay, from the lowest: compound 3; then compounds 1 and 2 (each within the scatter of the next).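

In this assay, this position proves sensitive to what the aromatic group carries: 3-hydroxyphenyl in place of 3-methylthiophen-2-yl gives a 4.2-fold lower number from compound 2 to compound 3 (0.62 log units; beyond the scatter), whereas the earlier exchange of 3-fluorophenyl for 3-methylthiophen-2-yl stayed within the scatter. Hydroxy in place of fluoro on an aromatic carbon gives a 3.4-fold lower number from compound 1 to compound 3 (0.53 log units; beyond the scatter), so this one substituent exchange on the phenyl ring is enough to move the number beyond the scatter. Of the three compounds, compound 3 now has the lowest number, with steps beyond the scatter to both others. From the compounds shown here alone, whether a methoxy group or an amine in place of the hydroxy would keep the number of compound 3 stays open. What lies behind the shift also stays open, as nothing available bears on its cause.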